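Notes on a methyl-to-hydrogen step in the amine side chain

The compounds below may be only part of what the source reports. "The series", "measured", "known", "first", "only" and "open" are said of these compounds alone.

Compound 1 `CNc1nc(-c2ccccc2)nc2c1nnn2Cc1ccccc1Cl` gives 191000000 nM in an assay on isolated protein for binding affinity to adenosine receptor A1 (Bos taurus); on this read-out higher numbers stand for weaker inhibition and lower numbers for stronger inhibition. Compound 2 `CCNc1nc(-c2ccccc2)nc2c1nnn2Cc1ccccc1Cl` gives 463000000 nM in this assay. Compound 2 and compound 1 differ by hydrogen in place of methyl on a saturated chain carbon bound to a nitrogen on an aromatic ring, and the step is a 2.4-fold lower number from compound 2 to compound 1 (0.38 log units; beyond the scatter). Compound 3 `CC(O)CNc1nc(-c2ccccc2)nc2c1nnn2Cc1ccccc1F` gives 4800000 nM in this assay, the lowest of the three numbers; the difference between the cores of compound 3 and compound 2 is not broken down here. Compound 4 `OCCNc1nc(-c2ccccc2)nc2c1nnn2Cc1ccccc1F` differs from compound 3 by hydrogen in place of methyl on a saturated chain carbon bound to an oxygen on a saturated carbon and a saturated chain carbon. The place is not the same: in the earlier pair the carbon is bound to a nitrogen on an aromatic ring, here it is bound to an oxygen on a saturated carbon and a saturated chain carbon, so this is the same kind of change, not the same change. A step of similar size is expected, a 1.9-fold lower number from compound 3 to compound 4 (0.28 log units; within the scatter), resting on the modest step from compound 2 to compound 1, a 2.4-fold lower number from compound 2 to compound 1 (0.38 log units; beyond the scatter). Compound 4 is therefore expected near 2500000 nM in this assay, estimated between 800000 nM and 8000000 nM.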

Compound 4, inhibition constant: 54000000 nM
Beside the measured number, compound 4's estimate is 22-fold (1.33 log units) below it, outside the stated range (above it).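

In this assay the methyl-to-hydrogen change does not carry over as a fixed step, and here it reads as an 11-fold higher number from compound 3 to compound 4 (1.05 log units; beyond the scatter). Set beside the earlier step, the new one runs in the opposite direction and the two do not agree: the same change on two cores in this assay, a 2.4-fold lower number (0.38 log units; beyond the scatter) from compound 2 to compound 1 and an 11-fold higher number (1.05 log units; beyond the scatter) from compound 3 to compound 4, 27-fold (1.44 log units) apart, beyond the scatter of two such steps. A step read in one place therefore gives neither size nor direction for another place in this series, but two pairs do not show whether the core or the place of the change sets the gap.

Open, going by these compounds, is how a longer chain, or an amine in place of the hydroxyl of the (2-hydroxyethyl)amino group, would read in this assay. Also open, on these data alone, is whether the change keeps this size on the core of compound 1.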